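A Trifluoromethyl Step Repeated on a Second Core

A few compounds are considered here, and "the series" means these few. Any claim that something is new, unique, unknown or untested is made for them only; others in the source may bear on it.

Measured compounds:
Compound 1, `CN(C)CCC(NC(=O)CCc1ccccc1)c1ccc(Cl)cc1`, gives 1660 nM.
Compound 2, `Cc1ccc(C(CCN(C)C)NC(=O)/C=C/c2ccccc2)cc1`, gives 1550 nM.
Compound 3, `CN(C)CCC(NC(=O)CCc1ccc(C(F)(F)F)cc1)c1ccc(Cl)cc1`, gives 1120 nM.

These three compounds were tested in a functional assay on NIH3T3 cells for agonist activity at Urotensin-2 receptor (Homo sapiens), with a stated time of 5 days; a higher number here means that more compound is needed for the effect, a lower number that less compound is needed. Compound 1 and compound 2 share neither a single counted difference; the difference between the two cores is not broken down here. Compound 3 is compound 1 with one change, (trifluoromethyl in place of hydrogen on an aromatic carbon), and the step it made was a 1.5-fold lower number from compound 1 to compound 3 (0.17 log units; within the scatter). Compound 1 and compound 2 give numbers that lie within the scatter of each other, so nothing separates them here.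

Compound 4, `Cc1ccc(C(CCN(C)C)NC(=O)/C=C/c2ccc(C(F)(F)F)cc2)cc1`, is the same change made on compound 2: trifluoromethyl in place of hydrogen on an aromatic carbon. The place lines of the two changes agree word for word, so this is the same change on a different core. Going by the values given here, with only one earlier example, in which compound 3 moved from compound 1 by a 1.5-fold lower number from compound 1 to compound 3 (0.17 log units; within the scatter), a step of similar small size is expected, not a large one. The step that this estimate means is a 1.5-fold lower number from compound 2 to compound 4 (0.17 log units; within the scatter), expected to stay within the scatter. Compound 4 is therefore expected to give about 1050 nM, with a likely range of 450 nM to 2500 nM.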

Compound 4, half-maximal effective concentration: 437 nM
For compound 4 the middle estimate is 2.4-fold (0.38 log units) above the measured one; the measured number lies below the stated range.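

In this assay, trifluoromethyl in place of hydrogen on an aromatic carbon gave a 3.5-fold lower number from compound 2 to compound 4 (0.55 log units; beyond the scatter), a modest step that, unlike the earlier one on the core of compound 1, stands clear of the scatter. Set side by side, the two steps cannot be told apart: the same change on two cores in this assay, a 1.5-fold lower number (0.17 log units; within the scatter) from compound 1 to compound 3 and a 3.5-fold lower number (0.55 log units; beyond the scatter) from compound 2 to compound 4, 2.4-fold (0.38 log units) apart, within the scatter of two such steps. The two pairs therefore fit a single step size carrying over from one core to the other, but they do not show that the change works better on the core of compound 2, and two pairs cannot show that it would hold on any further core.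

The compounds shown leave open whether a different group at the same place on the ring, such as a nitrile or a methoxy group, would give a similar step. They also leave open how the step would behave if the basic end of the molecule were changed, for example to a longer chain before the amine.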